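A few compounds are considered here, and "the series" means these few. Any claim that something is new, unique, unknown or untested is made for them only; others in the source may bear on it.

Of the compounds shown here, two with a shared five-membered core have so far been measured in an assay on membranes from brain for binding affinity to Monoglyceride lipase (Mus musculus), read by fluorescence, with stated times of 1 h and 30 min; a higher number here means a weaker inhibitor, a lower number a stronger inhibitor. Compound 1, `Cc1cnn(C(=O)NCc2ccc(OCc3ccccc3)cc2)c1`, gives 1000 nM. Compound 2, `Cc1cnn(C(=O)N2CCCCC2)c1`, gives 9200 nM, the higher of the two numbers; the gap to compound 1 is beyond the usual scatter, so compound 2 is the weaker inhibitor of the pair. Compound 3, `O=C(N1CCCCC1)n1cccn1`, has not yet been measured. It differs from compound 2 in one place: hydrogen in place of methyl on an aromatic carbon. Within the data shown here, no measured pair here shows what trimming this methyl does, so the expectation rests on compound 2 alone, whose value of 9200 nM already sits at the weak end. Compound 3 is expected to lose a little further, by a step of a 1.6-fold higher number from compound 2 to compound 3 (0.21 log units; within the scatter), though a result within the scatter of compound 2 would not surprise. Compound 3 is therefore estimated at 15000 nM, within a range from 5000 nM to 50000 nM.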

Compound 3, half-maximal inhibitory concentration: 6600 nM
The estimate for compound 3 lay 2.3-fold (0.36 log units) above the measured number, within the range that was stated.
By their numbers in this assay, from the lowest: compound 1; then compounds 3 and 2 (each within the scatter of the next).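

In this assay, hydrogen in place of methyl on an aromatic carbon of the five-membered ring gives a 1.4-fold lower number from compound 2 to compound 3 (0.14 log units; within the scatter). Among these compounds, this is the first pair here that differs in one place, and it shows that at this position, two ring bonds from the ring nitrogen, the methyl can give way to hydrogen without a change that can be told from the scatter. Nothing available here offers an explanation for this result.

The compounds shown leave open whether an ethyl, a methoxy or a chlorine atom on this same aromatic carbon would move the number beyond the scatter. They also leave open whether hydrogen in place of methyl would have as little effect in compound 1, which carries a different group on the carbonyl.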